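Cytotoxicity notes on a benzylimidazole aminobiphenyl series

This account rests on a few compounds, and the source may have more. Where it says the series, first, only, none or still open, it means among the compounds named here.

Measured so far:
- compound 1 `c1ccc(-c2ccc(Cn3cncc3CNc3ccc(-c4onc5ccccc45)c(-c4ccccc4)c3)cc2)cc1`: > 10000 nM
- compound 2 `COC(=O)c1ccc(NCc2cncn2Cc2ccccc2OC)cc1-c1ccccc1`: "not determined" (no result reported)

In a toxicity assay on NIH3T3 cells (Mus musculus) for cytotoxicity, read by resazurin assay (on this read-out higher numbers stand for an effect only at larger amounts of compound and lower numbers for an effect already at smaller amounts), compound 1 gives > 10000 nM; this is a limit of the assay, not a number. For compound 2 "not determined" (no result reported) stands in this assay, so no result was reported. Of the two values shown, one sits at the limit of > 10000 nM in this assay, at which 1 of the 2 values shown sits.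

Compound 3 `COC(=O)c1ccc(NCc2cncn2Cc2cccc(F)c2)cc1-c1ccccc1` differs from compound 2 by 3-fluorophenyl in place of 2-methoxyphenyl on a saturated chain carbon bound to an aromatic nitrogen. Among the compounds with values here, no measured step exists for this change, so its size and direction are unknown. Compound 3 is expected to give roughly 12000 nM in this assay, with a range from 3000 nM to 40000 nM, most likely reported only as a limit.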

Compound 3, half-maximal effective concentration: > 1000 nM
Compound 3 gave a limit, no number; the forecaster's own chance of this, stated with the estimate: 70%; the middle value does not contradict the limit.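

In this assay compound 3 gives > 1000 nM, which is a limit of the assay and not a number. Compound 2 has no reported result, so no step can be read between compound 2 and compound 3. The compounds shown leave open whether going from 2-methoxybenzyl to 3-fluorobenzyl changes cytotoxicity at all, and in which direction.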